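A few compounds are considered here, and "the series" means these few. Any claim that something is new, unique, unknown or untested is made for them only; others in the source may bear on it.

Measured so far:
- compound 1 `C=C1[C@@H](OC(C)=O)C[C@@H]2[C@](C)(COC=O)[C@H](OC(C)=O)CC[C@@]2(C)[C@@H]1C[C@@H](Nc1cccc(F)c1)C1=CCOC1=O`: 14100 nM
- compound 2 `C=C1[C@@H](OC(C)=O)C[C@@H]2[C@](C)(COC=O)[C@H](OC(C)=O)CC[C@@]2(C)[C@@H]1C/C=C1/C(=O)OC[C@H]1OC(C)=O`: 12900 nM

Both numbers come from a functional assay on MCF7 cells (Homo sapiens) for cytotoxicity, read by sulforhodamine B assay; a higher number here means a weaker inhibitor, a lower number a stronger inhibitor. On that read-out, compound 1 at 14100 nM and compound 2 at 12900 nM lie within the scatter of each other, so the two cannot be ranked. Both sit in the same range, and compound 1 is the only direct reference for the next analogue.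

Compound 3 `C=C1[C@@H](OC(C)=O)C[C@@H]2[C@](C)(COC=O)[C@H](OC(C)=O)CC[C@@]2(C)[C@@H]1C[C@@H](Nc1ccc(F)cc1)C1=CCOC1=O` keeps the core of compound 1 and differs in one place: 4-fluorophenyl in place of 3-fluorophenyl on an amine nitrogen. The two have the same atoms, joined differently.

Within the data shown here, no measured pair differs in one place, so the data give no step to size this change against, and nothing on how the position of the fluorine plays out. In this assay, no step beyond the scatter is expected, and neither direction is favoured. The expected step is small: a 1.2-fold lower number from compound 1 to compound 3 (0.07 log units; within the scatter). For compound 3 the estimate is 12000 nM, with an expected range from 5000 nM to 28000 nM.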

Compound 3, half-maximal inhibitory concentration: 12400 nM
For compound 3 the middle estimate is 1.0-fold (0.01 log units) below the measured one; measured number inside the range.
By their numbers in this assay, from the lowest: compounds 3, 2 and 1 (each within the scatter of the next).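

Among these compounds, exchanging 3-fluorophenyl for 4-fluorophenyl on the amine nitrogen supplies the first one-place step: in this assay the exchange gives a 1.1-fold lower number from compound 1 to compound 3 (0.06 log units; within the scatter) and so sets a first measured size for a change at this position. Compound 1 and compound 3 cannot be ranked, so for this pair the placement of the fluorine on the phenyl group does not separate the two on this read-out, and the finding goes no further than these two isomers. No supporting data on the origin of this result are at hand.

The compounds shown leave open whether the aryl group on this nitrogen matters at all, since the one step available only relocates a fluorine: an unsubstituted phenyl, a 4-chlorophenyl, a 4-methoxyphenyl or a saturated cyclohexyl on the same nitrogen would test the position with a real change of group. Also open, as far as these compounds go, is whether a group of a different kind on the phenyl ring, such as a hydroxyl or a carboxylic acid, would produce a step beyond the scatter in this assay at this position.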